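From acetamido to methylamino on a shared core

The compounds below may be only part of what the source reports. "The series", "measured", "known", "first", "only" and "open" are said of these compounds alone.

Measured in a physicochemical assay for lipophilicity, measured as octanol-water partition; on this read-out higher numbers stand for higher lipophilicity and lower numbers for lower lipophilicity:
- compound 1 `CC(C)CC(=O)Nc1nc2ccccc2s1`: 3.54
- compound 2 `CC(=O)Nc1nc2ccccc2s1`: 2.14
- compound 3 `CC(C)(C)C(=O)Nc1nc2ccccc2s1`: 4.07

Compound 2 stands lowest of the three, with both others beyond the scatter from it. Compound 4 `CNc1nc2ccccc2s1` has methyl in place of acetyl on a nitrogen on an aromatic ring. Among the measured compounds shown here, no measured step makes this change. The nearest evidence, a number 1.40 log units lower from compound 1 to compound 2 (beyond the scatter) and a number 1.93 log units higher from compound 2 to compound 3 (beyond the scatter), consists of two large steps, yet both keep the carbonyl, so they are only a loose guide. A small upward step in this assay is expected, an estimated a number 0.26 log units higher from compound 2 to compound 4 (within the scatter). The expected value for compound 4 is 2.4, within an estimated range of 2 to 2.9.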

Compound 4, partition coefficient: 2.73
The estimate for compound 4 lay 0.33 log units below the measured number; measured number inside the range.
By their numbers in this assay, from the lowest: compound 2; then compound 4; then compound 1; then compound 3.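

In this assay, among the compounds shown here, methyl in place of acetyl on a nitrogen on an aromatic ring gives a number 0.59 log units higher from compound 2 to compound 4 (beyond the scatter), the first step here that removes the carbonyl instead of changing the group attached to it. The entering group is smaller than the one leaving, yet the number rises, whereas the smaller group in a number 1.40 log units lower from compound 1 to compound 2 (beyond the scatter), came with a fall. Nothing available here accounts for this rise.

On these data alone, whether an unsubstituted amine or a longer chain on that nitrogen would follow compound 4 remains open. So does how much of the step belongs to losing the carbonyl alone.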